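Adding a Methoxy Group to the Phenyl Ring of Compound 2

The source may hold more compounds than are shown below. What is called first, only, known or untested is meant among the compounds shown, and "the series" means these compounds.

Of the compounds shown here, two have been tested so far in a functional assay on SMMC-7721 cells (Homo sapiens) for cytotoxicity, read by MTT assay, with a stated time of 4 days; a higher number here means a weaker inhibitor, a lower number a stronger inhibitor. Compound 1 `Cc1c(O)ccc2c1[C@H](Cn1cc(-c3ccc(F)cc3)nn1)[C@@]13CC(=O)[C@@](C)(CC[C@@H]21)C3` returns only a limit in this assay, > 20000 nM, which marks the edge of what the assay can report rather than a measured number. Compound 2 `C=C1C(=O)[C@]23C[C@@]1(O)CC[C@H]2c1ccc(O)c(C)c1[C@@H]3Cn1cc(-c2ccccc2)nn1` gives 1320 nM in this assay. Among the values shown, compound 2 therefore holds the only real number. The other value shown is a limit: the limit of > 20000 nM in this assay, at which 1 of the 2 values shown sits.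

Compound 3 `C=C1C(=O)[C@]23C[C@@]1(O)CC[C@H]2c1ccc(O)c(C)c1[C@@H]3Cn1cc(-c2ccc(OC)cc2)nn1` is compound 2 with a single change: methoxy in place of hydrogen on an aromatic carbon. For the measured compounds named here, no pair of measured compounds differs by this change alone, so there is no measured step to lean on, and the two measured compounds differ in several places at once, which prevents any direct comparison. The expected step from compound 2 to compound 3 is small, not clearly beyond the usual scatter in either direction, as written in a 1.1-fold higher number from compound 2 to compound 3 (0.06 log units; within the scatter). Compound 3 is accordingly expected to give about 1500 nM in this assay, with a likely range from 500 nM to 5000 nM.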

Compound 3, half-maximal inhibitory concentration: 860 nM
Beside the measured number, compound 3's estimate is 1.7-fold (0.24 log units) above it; low and high end bracket the measured number.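

In this assay, the change from phenyl to 4-methoxyphenyl gives a 1.5-fold lower number from compound 2 to compound 3 (0.19 log units; within the scatter). For the compounds shown here, this is the first comparison here between two compounds that differ in one place only, and it gives a step that cannot be told apart from the ordinary spread of repeated measurements. The aromatic carbon para to a large group can therefore carry methoxy, with its 2 heavy atoms and 1 hydrogen-bond acceptor, with no loss in this cell read-out that the data can detect, but none of the measurements shown explains why the step is this small.

One step at one place is a narrow basis, and it says nothing yet about how far this position tolerates larger or very different groups, such as an amine, a carboxylic acid or a longer chain like butoxy, or whether any of these would move the number clearly beyond the scatter. Going by these compounds, it also remains open whether a methoxy group on another carbon of the same aromatic ring would give a similar result.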